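The compounds below may be only part of what the source reports. "The series", "measured", "known", "first", "only" and "open" are said of these compounds alone.

Measured so far in an ADME assay on MDCK cells (Canis lupus familiaris) for cytotoxicity; on this read-out lower numbers stand for higher toxicity in this test and higher numbers for lower toxicity in this test:
Compound 1, `Cn1ccnc1Sc1cnc(-c2ccncc2)nc1-c1ccccc1O`: 64700 ug/mL
Compound 2, `Cc1ccc(O)c(-c2nc(C(C)(C)C)ncc2Sc2nccn2C)c1`: 116000 ug/mL

On the numbers shown compound 2 stands highest, but its gap to compound 1 is within the usual scatter, so the two cannot be told apart. Compound 3 is `Cn1ccnc1Sc1cnc(C(C)(C)C)nc1-c1ccccc1O`. It differs from compound 2 by hydrogen in place of methyl on an aromatic carbon. Among the measured compounds shown here, no measured pair shows what this change does here. The step of a 1.2-fold lower number from compound 2 to compound 3 (0.06 log units; within the scatter) is expected to stay within the scatter, with no clear direction. Compound 3 is estimated at 100000 ug/mL, between 45000 ug/mL and 220000 ug/mL.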

Compound 3, half-maximal cytotoxic concentration: 194000 ug/mL
The estimate for compound 3 lay 1.9-fold (0.29 log units) below the measured number; the range from low to high includes it.
By their numbers in this assay, from the lowest: compounds 1, 2 and 3 (each within the scatter of the next, the first and the last beyond it).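

Swapping the methyl para to the hydroxy group for hydrogen, which turns 2-hydroxy-5-methylphenyl into 2-hydroxyphenyl, gives in this assay a 1.7-fold higher number from compound 2 to compound 3 (0.22 log units; within the scatter), so this position shows no clear effect of that change. Tert-butyl in place of pyridin-4-yl gives a 3.0-fold higher number from compound 1 to compound 3 (0.48 log units; beyond the scatter), a modest step and the only one here beyond the scatter, pointing to lower toxicity in this test. No supporting measurement explains either step.

From the compounds shown here alone, whether a methoxy group or a chlorine atom at the methyl position would move the number remains open. So does whether an amine in place of tert-butyl would keep the higher number.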